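A few compounds are considered here, and "the series" means these few. Any claim that something is new, unique, unknown or untested is made for them only; others in the source may bear on it.

Measured compounds:
- compound 1 `CCCOCc1cc(O)c(O)c(Br)c1Br`: 1320 nM
- compound 3 `CCOCc1cc(Br)c(O)c(O)c1Br`: 1540 nM
- compound 2 `CCCOCc1cc(O)c(O)c(Br)c1`: "not determined" (no result reported)

All three were tested in a functional assay on HCT-116 cells (Homo sapiens) for cytotoxicity, read by MTT assay, with a stated time of 96 h; on this read-out lower numbers stand for stronger inhibition and higher numbers for weaker inhibition. Compound 1 gives 1320 nM and compound 3 gives 1540 nM; these two numbers lie within the scatter of each other, so neither compound can be ranked above the other. Compound 1 has the lower of the two numbers, but only by a margin inside the scatter, and compound 2 adds no number.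

Compound 4 `COCc1cc(O)c(O)c(Br)c1Br` has not yet been measured. It differs from compound 1 by hydrogen in place of ethyl on a saturated chain carbon bound to an oxygen on a saturated carbon. Going by the values given here, no step between measured compounds is available to guide the expectation, and the two values in hand sit close together. The step of a 1.2-fold higher number from compound 1 to compound 4 (0.08 log units; within the scatter) is therefore expected to stay within the scatter. Compound 4 is estimated to give 1600 nM, with a range from 700 nM to 3600 nM.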

Compound 4, half-maximal inhibitory concentration: 14100 nM
Compound 4: middle estimate off by 8.8-fold (0.95 log units), on the low side, and the stated range ends below it.
By their numbers in this assay, from the lowest: compounds 1 and 3 (each within the scatter of the next); then compound 4.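

In this assay the change from propoxy to methoxy gives an 11-fold higher number from compound 1 to compound 4 (1.03 log units; beyond the scatter) and so shows that this position does not tolerate every chain length. Losing the ethyl from the end of the chain is enough to weaken inhibition clearly, which the close values of the earlier compounds gave no sign of. Nothing measured here explains this loss.

As far as these compounds go, whether a longer chain such as butoxy would keep, improve or weaken the inhibition remains open. So does the effect of an amine at the end of the chain.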